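Swapping a Piperazine Amide for a Methoxybenzyl Amide

The source may report more compounds than this note shows. Statements on the series, on what has been measured and on what is new or still open speak of the compounds shown alone.

Going by the values given here, compound 1 `CC1CN(C(=O)c2c(N)sc(-c3ccc(Cl)cc3)c2-c2ccc(Cl)cc2)CCN1` is the stronger of the two compounds measured so far. In a functional assay on A549 cells (Homo sapiens) for inhibition, read by sulforhodamine B assay, with a stated time of 72 h (on this read-out lower numbers stand for stronger inhibition and higher numbers for weaker inhibition), compound 1 gives 4930 nM, the lowest of the two numbers. Compound 2 `CC(C)CNC(=O)c1c(N)sc(-c2ccc(Cl)cc2)c1-c1ccc(Cl)cc1` carries an open-chain isobutylamino group on the carbonyl carbon instead of the ring amine, and in this assay compound 2 gives 21000 nM; the change brought a 4.3-fold higher number from compound 1 to compound 2 (0.63 log units; beyond the scatter).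

Compound 3 `COc1ccc(CNC(=O)c2c(N)sc(-c3ccc(Cl)cc3)c2-c2ccc(Cl)cc2)cc1` is the next compound to be measured. It differs from compound 1 in one place: (4-methoxybenzyl)amino in place of 3-methylpiperazin-1-yl on a carbonyl carbon. Like the change from compound 1 to compound 2, this swap replaces the ring amine with an open-chain amine on the same carbonyl carbon. Among the compounds with values here, the only comparable step, from compound 1 to compound 2, weakened inhibition beyond the scatter, so a weakening of similar or somewhat smaller size is expected here, roughly a 2.4-fold higher number from compound 1 to compound 3 (0.39 log units; beyond the scatter). The expected value for compound 3 in this assay is therefore 12000 nM, with a range from 5000 nM to 30000 nM.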

Compound 3, half-maximal inhibitory concentration: 18200 nM
Compound 3: the middle estimate sits 1.5-fold (0.18 log units) below what was measured, and the stated range covers the measured number.
By their numbers in this assay, from the lowest: compound 1; then compounds 3 and 2 (each within the scatter of the next).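

In this assay, a second open-chain amine on the carbonyl carbon also falls short of the 3-methylpiperazin-1-yl group, with a 3.7-fold higher number from compound 1 to compound 3 (0.57 log units; beyond the scatter), so the loss seen with the isobutylamino group of compound 2 now appears with a quite different replacement as well. The two open-chain groups cannot be told apart here, with a 1.2-fold lower number from compound 2 to compound 3 (0.06 log units; within the scatter), so exchanging isopropyl for 4-methoxyphenyl on the saturated chain carbon bound to an amide-type nitrogen makes no readable difference, even though it brings in an aromatic ring. Among these three compounds, then, the ring amine of compound 1 stands apart from both open-chain amines, but no independent measurement is available to explain this difference.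

As far as these compounds go, what remains open is which part of the 3-methylpiperazin-1-yl group matters: its methyl group, its second ring nitrogen or the ring as a whole. A plain piperazin-1-yl group would test the methyl group, while a morpholin-4-yl group, with oxygen in place of that nitrogen, or an open-chain 2-aminoethylamino group, which keeps a second nitrogen without the ring, would help separate the other two.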